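Oxan-4-yl for cyclohexyl on a Ret kinase pyrazolopyrimidine

A few compounds are considered here, and "the series" means these few. Any claim that something is new, unique, unknown or untested is made for them only; others in the source may bear on it.

Measured compounds:
- compound 1, `Nc1ncnc2c1c(-c1cc(C3CC3)on1)nn2C1CCCCC1`: 2 nM
- compound 2, `CCc1cc(-c2nn(C(C)C)c3ncnc(N)c23)no1`: 41 nM

Of the compounds shown here, two have been measured in an assay on isolated protein for inhibition of proto-oncogene tyrosine-protein kinase receptor Ret (Homo sapiens), read by radiometric assay and 33P incorporation, in the presence of a further agent that is not named here; on this read-out lower numbers stand for stronger inhibition and higher numbers for weaker inhibition. Compound 1 carries a cyclohexyl group on the aromatic nitrogen and a 5-cyclopropyl-1,2-oxazol-3-yl group on the shared core; in this assay compound 1 gives 2 nM, the lowest of the two numbers. Its nearest neighbour is compound 2, whose value in this assay is 41 nM, a gap that lies beyond the usual scatter. Among the compounds with values here, compound 2 differs from compound 1 in more than one place, so no single step between them can be read.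

Compound 3, `Nc1ncnc2c1c(-c1cc(C3CC3)on1)nn2C1CCOCC1`, has not yet been measured. It differs from compound 1 in one place: oxan-4-yl in place of cyclohexyl on an aromatic nitrogen. Given that compound 1 stands at 2 nM in this assay, compound 3 is expected to stay close, with a step of a 2.0-fold higher number from compound 1 to compound 3 (0.30 log units; within the scatter) that is estimated to be small and, if anything, towards a slightly higher number. Compound 3 is therefore estimated to give 4 nM in this assay, within a range from 1.5 nM to 12 nM.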

Compound 3, half-maximal inhibitory concentration: 5 nM
For compound 3 the middle estimate is 1.3-fold (0.10 log units) below the measured one; low and high end bracket the measured number.
By their numbers in this assay, from the lowest: compound 1; then compound 3; then compound 2.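

In this assay, within the data shown here, the exchange of cyclohexyl for oxan-4-yl on the aromatic nitrogen gives the first step that can be read at this position: a 2.5-fold higher number from compound 1 to compound 3 (0.40 log units; beyond the scatter), which is modest but lies beyond the usual scatter. Both groups count six heavy atoms in a six-membered non-aromatic ring, so the change amounts to one ring carbon replaced by oxygen and the gain of one hydrogen-bond acceptor, and with that change compound 3 still gives 5 nM. The position therefore accepts this hetero atom in the ring at a small but real cost in this read-out, though nothing at hand accounts for the size or direction of the step.

What the compounds shown leave open is whether a ring amine, as in piperidin-4-yl, or a carboxylic acid or hydroxyl group on the cyclohexyl ring would stay as close to compound 1. Also open, as far as these compounds go, is whether the exchange of cyclohexyl for oxan-4-yl gives a step of similar size when the shared core carries a group other than 5-cyclopropyl-1,2-oxazol-3-yl.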